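Swapping the aryl group on a chalcone-type arm

This account rests on a few compounds, and the source may have more. Where it says the series, first, only, none or still open, it means among the compounds named here.

Measured compounds:
- compound 1 `Cc1cc(Nc2ccc(C(=O)/C=C/c3ccccc3Cl)cc2)n2nc(SCc3nc4ccccc4[nH]3)nc2n1`: 680 nM
- compound 2 `Cc1cc(Nc2ccc(C(=O)/C=C/c3ccc(C(F)(F)F)cc3)cc2)n2nc(SCc3nc4ccccc4[nH]3)nc2n1`: 1850 nM
- compound 3 `Cc1cc(Nc2ccc(C(=O)/C=C/c3ccc4ccccc4c3)cc2)n2nc(SC(=O)c3csc4ccc(Cl)cc34)nc2n1`: 35 nM

All three were tested in a functional assay on SW-620 cells (Homo sapiens) for cytotoxicity, read by MTT assay, with stated times of 4 h and 72 h, tested at 2 uM; on this read-out higher numbers stand for weaker inhibition and lower numbers for stronger inhibition. On these numbers compound 1 stands second highest of the three; its nearest neighbour is compound 2, and compound 3, which also carries a different sulfur-linked group on the shared core, lies far lower.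

Compound 4 `COc1ccc(/C=C/C(=O)c2ccc(Nc3cc(C)nc4nc(SCc5nc6ccccc6[nH]5)nn34)cc2)cc1` is not yet measured. It differs from compound 1 in one place: 4-methoxyphenyl in place of 2-chlorophenyl on a double-bonded chain carbon bound to a double-bonded chain carbon. Among the compounds with values here, the only measured step at this place is a 2.7-fold higher number from compound 1 to compound 2 (0.43 log units; beyond the scatter), where a different group entered the same position and the number rose modestly. Within the data shown here, that step involves a different entering group, so it gives direction only loosely; a methoxy-bearing ring has no measured precedent here. The expectation for compound 4 is therefore a small weakening or no change beyond the scatter, a 1.3-fold higher number from compound 1 to compound 4 (0.12 log units; within the scatter). Compound 4 is estimated at 900 nM, with a range from 300 nM to 2700 nM.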

Compound 4, half-maximal inhibitory concentration: 170 nM
Compound 4: middle estimate off by 5.3-fold (0.72 log units), on the high side; the whole stated range lies above it.
By their numbers in this assay, from the lowest: compound 3; then compound 4; then compound 1; then compound 2.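

In this assay, the aryl group on this double-bonded chain carbon can move the number in either direction. Changing 2-chlorophenyl to 4-methoxyphenyl gives the opposite result (a 4.0-fold lower number from compound 1 to compound 4 (0.60 log units; beyond the scatter)) to the earlier change to 4-(trifluoromethyl)phenyl (still a 2.7-fold higher number from compound 1 to compound 2 (0.43 log units; beyond the scatter)). Methoxy in place of trifluoromethyl on an aromatic carbon also gives a large step (an 11-fold lower number from compound 2 to compound 4 (1.04 log units; beyond the scatter)), so the group on this ring matters, though no measurement on hand speaks to what lies behind the difference.

Compounds 1 and 4 differ in both the group and its ring location, so 4-chlorophenyl or 2-methoxyphenyl would be needed to separate those two changes. The compounds shown also leave open how a hydroxyl or dimethylamino group on this ring would behave.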